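This account rests on a few compounds, and the source may have more. Where it says the series, first, only, none or still open, it means among the compounds named here.

Compound 2 `Cc1cnc(C[S+]([O-])C(c2ccccc2)c2ccccc2)nc1` gives 156000 nM in an assay on HEK293 cells for inhibition of sodium-dependent dopamine transporter (Homo sapiens), read by scintillation counting, with stated times of 5 min and 1 min; on this read-out lower numbers stand for stronger inhibition and higher numbers for weaker inhibition. It sits alongside compound 1 `COC1NN=C(C[S+]([O-])C(c2ccccc2)c2ccccc2)S1`, which gives 108000 nM in this assay, the step of a 1.4-fold higher number from compound 1 to compound 2 (0.16 log units; within the scatter) being within the scatter. Compound 3 `[O-][S+](Cc1csc(Br)c1)C(c1ccccc1)c1ccccc1` carries 5-bromothiophen-3-yl in place of 5-methylpyrimidin-2-yl on a saturated chain carbon bound to a sulfur. Among the compounds with values here, the one measured step that touches the same position, a 1.4-fold higher number from compound 1 to compound 2 (0.16 log units; within the scatter), exchanged one ring for another without moving the number beyond the scatter, and no other step bears on this change. The expected step of a 1.2-fold lower number from compound 2 to compound 3 (0.08 log units; within the scatter) therefore stays within the scatter. Compound 3 is thus estimated at 130000 nM in this assay, with a range from 50000 nM to 350000 nM.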

Compound 3, half-maximal inhibitory concentration: 16600 nM
Compound 3: middle estimate off by 7.8-fold (0.89 log units), on the high side; measured number below the stated range.
By their numbers in this assay, from the lowest: compound 3; then compounds 1 and 2 (each within the scatter of the next).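

The position on a saturated chain carbon bound to a sulfur is not indifferent to the ring it carries: in this assay, 5-bromothiophen-3-yl in place of 5-methylpyrimidin-2-yl gives a 9.4-fold lower number from compound 2 to compound 3 (0.97 log units; beyond the scatter), and the change of group gives a 6.5-fold lower number from compound 1 to compound 3 (0.81 log units; beyond the scatter). The earlier exchange had stayed within the scatter, so only this group has shown a modest gain here. No evidence is available to account for this difference.

The compounds shown leave open whether the bromine or the ring of 5-bromothiophen-3-yl carries the step. They also leave open how an amine or a carboxylic acid would read at this place.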